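Series notes: isobutyl for phenyl on the amide nitrogen

This account rests on a few compounds, and the source may have more. Where it says the series, first, only, none or still open, it means among the compounds named here.

Compound 1 `C=CC1=C(C(=O)Nc2ccccc2)C(c2ccc(Cl)c(Cl)c2)OC1` and compound 2 `C=CC1=C(C(=O)Nc2ccccc2)C(c2ccc(OC)cc2)OC1` share one core and differ only in the aryl group on the saturated ring carbon. In a functional assay on A549 cells (Homo sapiens) for cytotoxicity, read by MTT assay, with a stated time of 24 h (a higher number here means a weaker inhibitor, a lower number a stronger inhibitor), compound 1 gives only a limit of > 100000 nM. In this assay compound 2 likewise gives only a limit of > 100000 nM. The step that the two limits leave unreadable from compound 1 to compound 2 is therefore unreadable. Compound 2 thus stands at the limit of > 100000 nM in this assay, at which 2 of the 2 values shown sit, with no number of its own. Compound 3 `C=CC1=C(C(=O)NCC(C)C)C(c2ccc(OC)cc2)OC1` differs from compound 2 by isobutyl in place of phenyl on an amide-type nitrogen, that is, anilino to isobutylamino. No measured step touches the amide nitrogen, and the single step on record is unreadable, so nothing shown supports any size or direction for the change in this assay. The expected step is a number no higher from compound 2 to compound 3 (the limit leaves the size open), with a limit again the likeliest outcome. For compound 3 the estimate is 100000 nM, ranging from 30000 nM to 300000 nM.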

Compound 3, half-maximal inhibitory concentration: > 100000 nM
Compound 3 was reported as a limit; the forecaster's own chance of this, stated with the estimate: 80%; the middle value sits exactly at the limit.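

In this assay compound 3 gives only a limit, > 100000 nM. With compound 2 also at a limit, no new step can be read between compound 2 and compound 3. The compounds shown leave open whether changing the aryl group or the amide nitrogen group shifts the read-out at all: the limit of > 100000 nM in this assay, at which 3 of the 3 values shown sit.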